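From compound 3 to the carbamoyl compound 4

The compounds below may be only part of what the source reports. "The series", "measured", "known", "first", "only" and "open" are said of these compounds alone.

Values in a functional assay on HCT-116 cells (Homo sapiens) for antiproliferative activity, read by sulforhodamine B assay, with a stated time of 72 h; on this read-out higher numbers stand for weaker inhibition and lower numbers for stronger inhibition:
- compound 1 `Cn1ncc(Cl)c1-c1cc(C(=O)N[C@@H]2CN[C@H](CC(O)CO)C[C@H]2c2ccc(Cl)c(Cl)c2)oc1Cl`: 1110 nM
- compound 2 `Cn1ncc(Cl)c1-c1cc(C(=O)N[C@@H]2CN[C@H](CCN3CCC(O)CC3)C[C@H]2c2ccc(Cl)c(Cl)c2)oc1Cl`: 13700 nM
- compound 3 `Cn1ncc(Cl)c1-c1cc(C(=O)N[C@@H]2CN[C@H](CCCO)C[C@H]2c2ccc(Cl)c(Cl)c2)oc1Cl`: 510 nM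

Of the three compounds measured in this assay, compound 3 has the lowest number, with both others beyond the scatter from it. Its closest neighbour is compound 1, and hydrogen in place of hydroxy gives a 2.2-fold lower number from compound 1 to compound 3 (0.34 log units; beyond the scatter). The side chain of compound 2 lies much further off, as shown by a 27-fold lower number from compound 2 to compound 3 (1.43 log units; beyond the scatter) and by a 12-fold higher number from compound 1 to compound 2 (1.09 log units; beyond the scatter).

The next compound is compound 4 `Cn1ncc(Cl)c1-c1cc(C(=O)N[C@@H]2CN[C@H](CC(N)=O)C[C@H]2c2ccc(Cl)c(Cl)c2)oc1Cl`, which carries carbamoyl in place of 2-hydroxyethyl on a saturated chain carbon bound to a saturated ring carbon. Among the compounds with values here, no measured compound carries a carbamoyl, so no measured step matches this change directly. All three steps are side chain changes, and all of them lead to a higher number when moving away from compound 3. The small chain of compound 1, at 1110 nM, is the closer guide, while the large step to compound 2 involves a ring that compound 4 lacks. A modest to moderate rise is therefore expected in this assay, though the uncertainty is wide.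

The estimated change is a 2.7-fold higher number from compound 3 to compound 4 (0.44 log units; beyond the scatter). For compound 4 the expected value is 1400 nM, with an estimated range of 450 nM to 4500 nM.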

Compound 4, half-maximal inhibitory concentration: 650 nM
Beside the measured number, compound 4's estimate is 2.2-fold (0.33 log units) above it, and the stated range covers the measured number.
By their numbers in this assay, from the lowest: compounds 3, 4 and 1 (each within the scatter of the next, the first and the last beyond it); then compound 2.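

In this assay, carbamoyl on a saturated chain carbon bound to a saturated ring carbon reads level with 2-hydroxyethyl, with a 1.3-fold higher number from compound 3 to compound 4 (0.11 log units; within the scatter) and so no change beyond the scatter, and this is the first side chain shown here that carries no hydroxy group, so among these compounds a terminal hydroxy is not needed to hold the number at this level. Compound 4 is also level with the 1,2-dihydroxyethyl chain of compound 1, as a 1.7-fold lower number from compound 1 to compound 4 (0.23 log units; within the scatter) shows, whereas the (4-hydroxypiperidin-1-yl)methyl chain stands well apart, with a 21-fold lower number from compound 2 to compound 4 (1.32 log units; beyond the scatter) as a large step, which leaves compound 2 as the one exception among the four compounds. No measurement given here accounts for why these side chains read alike or why compound 2 departs from them.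

The compounds shown leave open how a carboxylic acid or a simple primary amine would read in place of the carbamoyl, and whether a longer chain ending in carbamoyl would stay level with compound 3. They also leave open whether the step to compound 2 belongs to the piperidine ring itself or to its nitrogen, which a cyclohexyl chain could separate.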